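Cytotoxicity notes on a hydrazone series: step to compound 4

The compounds below may be only part of what the source reports. "The series", "measured", "known", "first", "only" and "open" are said of these compounds alone.

Measured in an ADME assay on NIH3T3 cells (Mus musculus) for cytotoxicity, read by MTT assay, with a stated time of 24 h (on this read-out higher numbers stand for weaker inhibition and lower numbers for stronger inhibition), so far:
compound 1, `O=C(CSc1nnc(-c2ccncc2)o1)N/N=C/c1ccccc1`, 167000 nM;
compound 2, `O=C(CSc1nnc(-c2ccncc2)o1)N/N=C/c1ccc(O)cc1`, 158000 nM;
compound 3, `O=C(CSc1nnc(-c2ccncc2)o1)N/N=C/c1cccc(F)c1`, 205000 nM.

Compound 3 nominally carries the highest of the three numbers, yet a 1.2-fold higher number from compound 1 to compound 3 (0.09 log units; within the scatter) and a 1.3-fold higher number from compound 2 to compound 3 (0.11 log units; within the scatter) both sit within the scatter, so the three compounds cannot be told apart in this assay . Compound 4, `O=C(CSc1nnc(-c2ccncc2)o1)N/N=C/c1cc(Cl)ccc1O`, differs from compound 3 by 5-chloro-2-hydroxyphenyl in place of 3-fluorophenyl on a carbon with a double bond to nitrogen. For the measured compounds named here, the steps that bear on a substituent change on this aryl ring are a 1.1-fold lower number from compound 1 to compound 2 (0.02 log units; within the scatter), a 1.2-fold higher number from compound 1 to compound 3 (0.09 log units; within the scatter) and a 1.3-fold higher number from compound 2 to compound 3 (0.11 log units; within the scatter), none beyond the scatter. No step beyond the scatter is therefore expected in this assay , i.e. a 1.1-fold lower number from compound 3 to compound 4 (0.06 log units; within the scatter) is expected. Compound 4 is estimated at 180000 nM, range 90000 nM to 360000 nM.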

Compound 4, half-maximal inhibitory concentration: 166000 nM
For compound 4 the middle estimate is 1.1-fold (0.04 log units) above the measured one, within the range that was stated.
By their numbers in this assay, from the lowest: compounds 2, 4, 1 and 3 (each within the scatter of the next).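

Replacing a single-substituent or unsubstituted aryl ring with 5-chloro-2-hydroxyphenyl, which carries chloro and hydroxy together, on the carbon with a double bond to nitrogen still gives only small steps in this assay: a 1.2-fold lower number from compound 3 to compound 4 (0.09 log units; within the scatter), a 1.1-fold higher number from compound 2 to compound 4 (0.02 log units; within the scatter) and a 1.0-fold lower number from compound 1 to compound 4 (0.00 log units; within the scatter). All four aryl variants therefore remain indistinguishable, now including one with both substituents on the ring. No available evidence accounts for this flat response.

Open, on these data alone, is whether an amine or a carboxylic acid on this ring, or a longer chain in its place, would give a step beyond the scatter.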